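Replacing the dimethylamino group of compound 2 with hydrogen

The compounds below may be only part of what the source reports. "The series", "measured", "known", "first", "only" and "open" are said of these compounds alone.

compound 1 `CCOc1c(NC)cnn(C)c1=O` gives 55 mg/kg
compound 2 `CCOc1c(N(C)C)cnn(C)c1=O` gives 86 mg/kg
compound 3 `CCOc1c(N2CCN(C)CC2)cnn(C)c1=O` gives 82 mg/kg

In a functional assay on the whole organism (Abdomen, strain ddY) for inhibition, with Mus musculus as the target, with stated times of 30 min and 20 min (on this read-out lower numbers stand for an effect already at smaller amounts and higher numbers for an effect only at larger amounts of compound), compound 2 lies within the scatter of both compound 1 and compound 3, so these three values do not separate. Compound 4 `CCOc1ccnn(C)c1=O` has hydrogen in place of dimethylamino on an aromatic carbon. Among the compounds with values here, the one measured step that bears on this group, a 1.6-fold higher number from compound 1 to compound 2 (0.19 log units; within the scatter), is small. Compound 3 carries a ring-bearing group instead and also stays within the scatter of compound 2. Within the data shown here, no measured compound has hydrogen there, so the expectation is uncertain, but no shift beyond the scatter is expected in this assay. The expected step is a 1.1-fold lower number from compound 2 to compound 4 (0.03 log units; within the scatter). For compound 4 the estimated value is 80 mg/kg, with an expected range from 35 mg/kg to 190 mg/kg.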

Compound 4, dose for half-maximal effect: > 100 mg/kg
Compound 4 ended at the assay's limit; the forecaster's own chance of this, stated with the estimate: 10%; middle value at least 1.2-fold (0.09 log units) from the limit.
By their numbers in this assay, from the lowest: compounds 1, 3 and 2 (each within the scatter of the next). At a limit, above all of these: compound 4.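

In this assay compound 4, the only compound shown with hydrogen on this aromatic carbon, gives > 100 mg/kg, which is a limit of the assay. Hydrogen in place of dimethylamino gives an at least 1.1-fold higher number from compound 2 to compound 4 (0.06 log units; that floor lies within the scatter), and hydrogen in place of methylamino gives an at least 1.8-fold higher number from compound 1 to compound 4 (0.25 log units; that floor lies within the scatter). Only the compounds with a nitrogen-linked group at this position give a number here, yet neither floor shows a step beyond the scatter.

On these data alone, the true size of both steps stays open. So does whether a primary amine or a methoxy group on this carbon would match the nitrogen-linked groups or hydrogen.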